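Expecting the 4-(trifluoromethoxy)phenyl analogue of compound 3

The source may report more compounds than this note shows. Statements on the series, on what has been measured and on what is new or still open speak of the compounds shown alone.

Three compounds built on one shared core were tested in a functional assay on CHO cells with adenosine receptor A1 (Homo sapiens) as the target, read by cAMP accumulation and immunoassay, with a stated time of 6 min, tested at 0.01 uM; a higher number here means a weaker effect of the compound at the concentration tested, a lower number a stronger effect. Compound 1 `Nc1scc(CN2CCN(c3ccc(Cl)cc3Cl)CC2)c1C(=O)c1ccc(Cl)cc1` gives 2%, compound 2 `Nc1scc(CN2CCN(c3ccc(Cl)cc3F)CC2)c1C(=O)c1ccc(Cl)cc1` gives -9.2%, and compound 3 `Nc1scc(CN2CCN(c3ccc(Cl)c(C(F)(F)F)c3)CC2)c1C(=O)c1ccc(Cl)cc1` gives -2.5%. Compound 3 thus holds the second highest of the three numbers: its nearest neighbour is compound 1, with a number 4.5 percentage points lower from compound 1 to compound 3 (within the scatter), and its furthest is compound 2, with a number 6.7 percentage points higher from compound 2 to compound 3 (within the scatter), both within the scatter. For the measured compounds named here, the only step beyond the scatter among the three is a number 11.2 percentage points lower from compound 1 to compound 2 (beyond the scatter), the replacement of a chloro by a fluoro on an aromatic carbon.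

Compound 4 `Nc1scc(CN2CCN(c3ccc(OC(F)(F)F)cc3)CC2)c1C(=O)c1ccc(Cl)cc1` differs from compound 3 in one place: 4-(trifluoromethoxy)phenyl in place of 4-chloro-3-(trifluoromethyl)phenyl on an amine nitrogen in a ring. The two steps that bear on this change are the two earlier swaps of the group on the amine nitrogen in the ring, leading into compound 3 from compound 1 and from compound 2; both stayed within the scatter, and all three measured numbers in this assay sit close to zero. No step beyond the scatter is therefore expected, and the expected step is a number 2.5 percentage points higher from compound 3 to compound 4 (within the scatter). Compound 4 is estimated at 0% in this assay, with a range from -12% to 12%.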

Compound 4, a percentage reported as activity, at one concentration (the size of the read-out at that concentration, not a potency): 0%
For compound 4 middle estimate and measured number coincide at the digits printed, within the range that was stated.
By their numbers in this assay, from the lowest: compounds 2, 3, 4 and 1 (each within the scatter of the next, the first and the last beyond it).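

In this assay the change to 4-(trifluoromethoxy)phenyl on the amine nitrogen in the ring gives a number 2.5 percentage points higher from compound 3 to compound 4 (within the scatter) and a number 9.2 percentage points higher from compound 2 to compound 4 (within the scatter) and also a number 2 percentage points lower from compound 1 to compound 4 (within the scatter). Until now every group at this position carried a chlorine and no hydrogen-bond acceptor, whereas the group in compound 4 has an oxygen, one hydrogen-bond acceptor and no chlorine, and the number still stays within the scatter of all three earlier compounds, even though compound 1 and compound 2 lie beyond the scatter of each other. Nothing measured here explains this tolerance of the position.

As far as these compounds go, whether a phenyl carrying an amine or a carboxylic acid, or a longer alkyl chain in place of the phenyl on this nitrogen, would move the number beyond the scatter stays open. Also open is whether these four compounds, which all read close to zero at the one concentration shown, would separate at other concentrations, as this read-out gives the size of the effect at that concentration and not a potency.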